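A few compounds are considered here, and "the series" means these few. Any claim that something is new, unique, unknown or untested is made for them only; others in the source may bear on it.

Compound 1 `C=CCCCCOc1ccc2c(=O)c(-c3ccc(O)cc3)coc2c1` and compound 2 `O=c1c(-c2ccc(O)cc2)coc2cc(OCCCCCCO)ccc12` share one core and differ only at the far end of a chain attached through an oxygen on an aromatic ring. In an assay (Cricetulus griseus) for inhibition of aldehyde dehydrogenase, mitochondrial (Homo sapiens) (on this read-out higher numbers stand for weaker inhibition and lower numbers for stronger inhibition), compound 1 gives 150 nM, and in this assay compound 2 gives 120 nM; the step of a 1.3-fold lower number from compound 1 to compound 2 (0.10 log units; within the scatter) leaves the two within the scatter, so compound 2 stands level with compound 1 on the numbers shown. Compound 3 `O=C(O)COc1ccc2c(=O)c(-c3ccc(O)cc3)coc2c1` alters the same chain more deeply: carboxy in place of 5-hydroxypentyl on a saturated chain carbon bound to an oxygen on an aromatic ring. The single measured step, from compound 1 to compound 2, exchanges one chain end for another and stays within the scatter; no measured step removes most of the chain or brings in a carboxy group, so the direction of this change rests on no comparison shown here. The expectation for compound 3 is therefore a modest move toward a higher number, a 3.3-fold higher number from compound 2 to compound 3 (0.52 log units; beyond the scatter), with wide uncertainty. Compound 3 is estimated at 400 nM, with a range from 100 nM to 1600 nM.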

Compound 3, half-maximal inhibitory concentration: 1200 nM
Beside the measured number, compound 3's estimate is 3.0-fold (0.48 log units) below it, and the stated range covers the measured number.
By their numbers in this assay, from the lowest: compounds 2 and 1 (each within the scatter of the next); then compound 3.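

Until now, changing the end of the chain left the number within the scatter. Carboxy in place of the longer chains is the first change at this position to go beyond it, with a 10-fold higher number from compound 2 to compound 3 (1.00 log units; beyond the scatter) and an 8.0-fold higher number from compound 1 to compound 3 (0.90 log units; beyond the scatter) in this assay, so compound 3 is the weakest inhibitor of the three. The chain at this position therefore tolerates a change at its far end, but not this swap of a long chain for a short one ending in carboxy, and no measurement shown gives a reason for the shift.

Both steps shorten the chain and bring in carboxy together, so the compounds shown do not separate the effect of chain length from that of the carboxy group. From the compounds shown here alone, how an amine at the end of the chain, or a short chain ending in a hydroxyl group, would fare also remains open.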